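This account rests on a few compounds, and the source may have more. Where it says the series, first, only, none or still open, it means among the compounds named here.

Measured compounds in an assay on isolated protein for inhibition of Retinaldehyde dehydrogenase 3 (Homo sapiens); a higher number here means a weaker inhibitor, a lower number a stronger inhibitor:

compound 1 `Cn1ncc2c(=O)n(-c3ccccc3)c(SC(C)(C)c3ccccc3)nc21`, 1390 nM
compound 2 `CC(Sc1nc2c(cnn2C)c(=O)n1-c1ccccc1)c1cccc(F)c1`, 128 nM
compound 3 `COc1ccccc1C(C)Sc1nc2c(cnn2C)c(=O)n1-c1ccccc1`, 112 nM

Compound 3 carries the lowest of the three numbers in this assay, though compound 2 lies within the scatter of it; only compound 1 sits clearly apart, beyond the scatter. The series is small and all three share one core, differing only in the group on the sulfur.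

Compound 4 is `CC(Sc1nc2c(cnn2C)c(=O)n1-c1ccccc1)c1cncnc1`. The change from compound 3 is pyrimidin-5-yl in place of 2-methoxyphenyl on a saturated chain carbon bound to a saturated chain carbon and a sulfur. One measured step speaks most directly to it: the exchange of one aryl for another on the same saturated chain carbon, a 1.1-fold lower number from compound 2 to compound 3 (0.06 log units; within the scatter), which stayed within the scatter. The large step of an 11-fold lower number from compound 1 to compound 2 (1.04 log units; beyond the scatter) altered the chain as well as the aryl and so bears only loosely on this change. Going by these compounds, a pyrimidin-5-yl in place of a carbon-only ring is untested here; the expectation is a small step, if any, leaning toward a higher number.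

For compound 4 the estimated value in this assay is 220 nM, with a range of 80 nM to 650 nM. This estimate corresponds to an expected step of a 2.0-fold higher number from compound 3 to compound 4 (0.29 log units; within the scatter).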

Compound 4, half-maximal inhibitory concentration: 100 nM
Beside the measured number, compound 4's estimate is 2.2-fold (0.34 log units) above it; measured number inside the range.
By their numbers in this assay, from the lowest: compounds 4, 3 and 2 (each within the scatter of the next); then compound 1.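

On the saturated chain carbon bound to a saturated chain carbon and a sulfur, pyrimidin-5-yl reads level with both carbon-only rings in this assay, with a 1.1-fold lower number from compound 3 to compound 4 (0.05 log units; within the scatter) and a 1.3-fold lower number from compound 2 to compound 4 (0.11 log units; within the scatter), so a ring with 2 hetero atoms and 2 hydrogen-bond acceptors is accepted here as readily as 2-methoxyphenyl or 3-fluorophenyl. The large gap to compound 1 also persists with this ring, at a 14-fold lower number from compound 1 to compound 4 (1.14 log units; beyond the scatter), although that step changes the chain as well as the ring. Nothing available accounts for why these three rings read alike.

Going by these compounds, whether an amine or a carboxylic acid on the pyrimidin-5-yl ring would keep this level remains open. So does whether a longer chain in place of 1-(pyrimidin-5-yl)ethyl on the sulfur would.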